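Cytotoxicity notes: furan ketone replacing methylphenyl ketone

The compounds below may be only part of what the source reports. "The series", "measured", "known", "first", "only" and "open" are said of these compounds alone.

In an ADME assay on RAW264.7 cells (Mus musculus) for cytotoxicity, read by MTT assay (a lower number here means a stronger inhibitor, a higher number a weaker inhibitor), compound 1 (`Cc1cc(C(=O)/C=C/C=C/c2ccccc2)c(C)o1`) gives > 100000 nM, which is a limit of the assay and not a number. Compound 2 (`COc1ccc(/C=C/C=C/C(=O)c2ccc(C)cc2)cc1`) has no result, reading "not determined" (no result reported), so it has no position on the numbers. Compound 3 (`COc1ccc(/C=C/C=C/C(=O)c2cc(C)oc2C)cc1`) is the next structure. The change 2,5-dimethylfuran-3-yl in place of 4-methylphenyl on a carbonyl carbon puts 2,5-dimethylfuran-3-yl in place of 4-methylphenyl on a carbonyl carbon. For the measured compounds named here, no measured step is available to size this change, so no shift beyond the scatter is expected in this assay, in either direction. The only anchor is the limit of > 100000 nM in this assay, at which 1 of the 2 values shown sits. For compound 3 the expected value is 100000 nM, with an estimated range of 30000 nM to 300000 nM.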

Compound 3, half-maximal inhibitory concentration: > 100000 nM
Compound 3 was reported as a limit; the forecaster's own chance of this, stated with the estimate: 70%; the middle value lies on the limit itself.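

Compound 1 and compound 3 both stand at a limit of the assay, not a number, so no step between them can be read: the limit of > 100000 nM in this assay, at which 2 of the 3 values shown sit.

The compounds shown leave open whether methoxy in place of hydrogen on an aromatic carbon changes the read-out in this assay at all.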